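Swapping a Carboxybutyl Arm for Diethylamino

The source may hold more compounds than are shown below. What is called first, only, known or untested is meant among the compounds shown, and "the series" means these compounds.

Of the compounds shown here, two sharing one long-chain core have been measured in a functional assay on Jurkat cells (Homo sapiens) for inhibition; on this read-out lower numbers stand for stronger inhibition and higher numbers for weaker inhibition. Compound 1 `CCCCCCCCCCCCCCC(CNCC)NC(=O)OC(C)(C)C` gives 6000 nM in this assay, and compound 2 `CCCCCCCCCCCCCCC(CNCCCCC(=O)O)NC(=O)OC(C)(C)C` gives 18000 nM. The only difference between them is a 3.0-fold higher number from compound 1 to compound 2 (0.48 log units; beyond the scatter), so compound 2 stands as the higher of the two numbers, with compound 1 as its nearest neighbour.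

Compound 3 `CCCCCCCCCCCCCCC(CN(CC)CC)NC(=O)OC(C)(C)C` is not yet measured. It differs from compound 2 by diethylamino in place of (4-carboxybutyl)amino on a saturated chain carbon, two bonds along the chain from an amide-type nitrogen. Part of this change is the reverse of the one measured step: removing the carboxybutyl arm retraces a 3.0-fold higher number from compound 1 to compound 2 (0.48 log units; beyond the scatter) in the opposite direction, which would bring the number back toward that of compound 1. Going by the values given here, the remaining part, an added ethyl group turning the amine into a tertiary one, has no measured counterpart here, so its effect is unknown. On the strength of the measured step alone, a modest decrease in the number, a 3.0-fold lower number from compound 2 to compound 3 (0.48 log units; beyond the scatter), is expected. Compound 3 is therefore estimated at 6000 nM in this assay, with a range from 2000 nM to 18000 nM.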

Compound 3, half-maximal inhibitory concentration: 21000 nM
Beside the measured number, compound 3's estimate is 3.5-fold (0.54 log units) below it, outside the stated range (above it).
By their numbers in this assay, from the lowest: compound 1; then compounds 2 and 3 (each within the scatter of the next).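

In this assay, diethylamino in place of (4-carboxybutyl)amino gives a difference that stays within the scatter (a 1.2-fold higher number from compound 2 to compound 3 (0.07 log units; within the scatter)), so the two groups cannot be told apart on this read-out, although only one of them ends in a carboxylic acid. The added ethyl on the amine nitrogen of compound 1 gives a difference beyond the scatter (a 3.5-fold higher number from compound 1 to compound 3 (0.54 log units; beyond the scatter)), which shows that a compound without the carboxybutyl arm can still sit well away from compound 1, and that a single ethyl on this nitrogen is enough to produce a modest step. No measurement available here explains either result.

As far as these compounds go, it remains open whether the number of compound 2 follows from the length of its arm or from the carboxylic acid at its end, a question that a plain butyl group on the amine nitrogen, or a shorter chain ending in a carboxylic acid, could help separate. From the compounds shown here alone, it is also open how the number would respond to a primary amine at this position, with both ethyl groups gone.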